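Benzyloxy series: side chain at the saturated carbon

The compounds below may be only part of what the source reports. "The series", "measured", "known", "first", "only" and "open" are said of these compounds alone.

Measured:
compound 1, `Cc1nc2c(OCc3ccccc3)cccn2c1CCC#N`: 20%
compound 2, `CSCc1c(C)nc2c(OCc3ccccc3)cccn12`: 8%

In a functional assay on the whole organism (stomach) for inhibition, with Canis familiaris (Canis lupus familiaris) as the target, at a dose of 5 mg/kg by the intravenous route (a lower number here means a weaker effect, a higher number a stronger effect of the compound at the dose given), compound 1 stands highest of the two numbers; the nearest is compound 2, where the step of a number 12 percentage points lower from compound 1 to compound 2 (beyond the scatter) goes with the change from cyanomethyl to methylsulfanyl. Compound 3, `CCSCc1c(C)nc2c(OCc3ccccc3)cccn12`, has not been measured. Among the measured compounds shown here, it differs from compound 1 by ethylsulfanyl in place of cyanomethyl on a saturated chain carbon bound to an aromatic carbon, a change that resembles the one measured step. That step was modest and downward, so a step of about the same size downward is expected here, a number 10 percentage points lower from compound 1 to compound 3 (within the scatter). For compound 3 the inhibition in this assay is estimated at 10%, between 0% and 25%.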

Compound 3, a percentage reported as inhibition, in the whole organism at one dose (the size of the read-out at that dose, not a potency): 0%
Compound 3: middle estimate off by 10 percentage points, on the high side; the range from low to high includes it.
By their numbers in this assay, from the lowest: compounds 3 and 2 (each within the scatter of the next); then compound 1.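

In this assay, ethylsulfanyl in place of cyanomethyl on a saturated chain carbon bound to an aromatic carbon gives a second drop (a number 20 percentage points lower from compound 1 to compound 3 (beyond the scatter)), so both sulfur side chains read lower than the nitrile side chain of compound 1. Methyl in place of hydrogen on a saturated chain carbon bound to a sulfur separates nothing (a number 8 percentage points lower from compound 2 to compound 3 (within the scatter)), and compound 2 and compound 3 cannot be told apart. Nothing at hand explains the drop.

Open: whether an amine, a carboxylic acid or a longer nitrile chain at this place would hold or raise the inhibition.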